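The compounds below may be only part of what the source reports. "The series", "measured", "known", "first", "only" and "open" are said of these compounds alone.

Compound 1 `Nc1ncc(CNC(=O)Nc2ccc(S(=O)(=O)c3ccccc3)cc2)cn1`: 3 mL/min/kg
Compound 2 `O=C(NCc1cccnc1)Nc1ccc(S(=O)(=O)N2C3CCC2COC3)cc1`: 8 mL/min/kg

These two compounds have been tested in an ADME assay on microsomes from liver (Homo sapiens) for pharmacokinetics, read by LC-MS, with a stated time of 60 min, tested at 1 uM; a higher number here means faster removal of the compound, a lower number slower removal. Compound 2 gives 8 mL/min/kg, the higher of the two numbers, and this gap to compound 1 lies beyond the usual scatter of repeated measurements. Among the measured compounds shown here, only two compounds have numbers so far, so compound 2 cannot be placed within any broad range.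

Compound 3 `CC1CCN(S(=O)(=O)c2ccc(NC(=O)NCc3cccnc3)cc2)CCN1` has not yet been measured. It keeps the rest of compound 2 and changes only the group on a sulfonyl sulfur: a group of 8 heavy atoms (6 carbon, 2 nitrogen; one seven-membered non-aromatic ring with 2 hetero atoms) in place of a group of 8 heavy atoms (6 carbon, 1 nitrogen, 1 oxygen; one five-membered non-aromatic ring with 1 hetero atom, one six-membered non-aromatic ring with 2 hetero atoms), on a sulfonyl sulfur. For the measured compounds named here, the two measured compounds differ in more than one place, so no measured step shows what this exchange does, and any expectation is uncertain.

The starting point is therefore compound 2 at 8 mL/min/kg, the closest measured relative. A small upward move that stays within the scatter is expected, an estimated 1.3-fold higher number from compound 2 to compound 3 (0.10 log units; within the scatter). The new group shares no ring with the old one, so the range is kept wide. Compound 3 is expected at about 10 mL/min/kg, within an estimated range of 4 mL/min/kg to 25 mL/min/kg.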

Compound 3, clearance: 5 mL/min/kg
The estimate for compound 3 lay 2.0-fold (0.30 log units) above the measured number; measured number inside the range.
By their numbers in this assay, from the lowest: compounds 1, 3 and 2 (each within the scatter of the next, the first and the last beyond it).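

Among the compounds shown here, on the sulfonyl sulfur, whose other neighbour is an aromatic carbon, replacing the group with a five-membered and a six-membered ring by the group with one seven-membered ring gives the first single-place comparison in this assay, with a 1.6-fold lower number from compound 2 to compound 3 (0.20 log units; within the scatter). This step cannot be told apart from the variation seen between repeated measurements, so this pair shows that two quite different ring groups can occupy this position without a clear difference in the read-out, even though the entering group has 1 hydrogen-bond donor and the leaving group has 0. No supporting measurement is available that would account for this result.

The compounds shown leave open whether an open-chain dimethylamino group or a single six-membered piperidine ring on the same sulfonyl sulfur would also stay within the scatter of compound 2 and compound 3. They also leave open whether a carboxylic acid or a fluorine atom attached to the seven-membered ring would produce a step beyond the scatter.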